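This account rests on a few compounds, and the source may have more. Where it says the series, first, only, none or still open, it means among the compounds named here.

Working notes on the series

The three measured compounds share one core and differ in the chains and amine substituents around it. Compound 1 `COCC(C)Oc1nc(N2CCCCC2)c2nc(OC(C)COC)nc(N3CCCCC3)c2n1` gives, in a functional assay on L1210 cells (Mus musculus) for inhibition, read by thymidine incorporation, tested at 10 uM (on this read-out higher numbers stand for a stronger effect at the one concentration tested and lower numbers for a weaker effect), a value of 62%. Compound 2 `COCCOc1nc(NCc2ccccc2)c2nc(OCCOC)nc(NCc3ccccc3)c2n1` gives in this assay a value of 78%. Compound 3 `OCC(O)COc1nc(N2CCCCC2)c2nc(OC[C@H](O)CO)nc(N3CCCCC3)c2n1` gives in this assay a value of 32%, the lowest of the three numbers: compound 1 is the nearest to it and compound 2 the furthest, and both gaps lie beyond the scatter. No pair among these three differs in one place only, so no single-point step is available to gauge any change.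

Compound 4 `OCC(O)COc1nc(N2CCCCC2)c2nc(OCC(O)CO)nc(N3CCCCC3)c2n1` is the next entry. Relative to compound 3 the change is the two compounds have the same atoms and bonds; at least one stereo element is drawn with a configuration in one of them and without one in the other: 1 of 2 stereo elements differ; a stereocentre at a saturated chain carbon is drawn R in compound 3 and without a configuration in compound 4. Going by the values given here, no pair of measured compounds tests what a change in drawn configuration alone does. With identical atoms and bonds, the expectation in this assay is no step beyond the scatter, in either direction. Compound 4 is therefore expected to give about 32%, within 18% to 48%. The step estimated for no change at the digits printed from compound 3 to compound 4 (within the scatter) is expected to be flat.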

Compound 4, a percentage reported as inhibition, at one concentration (the size of the read-out at that concentration, not a potency): 32%
Compound 4: the middle estimate sits on the measured number at the digits printed; the range from low to high includes it.
By their numbers in this assay, from the lowest: compounds 3 and 4 (each within the scatter of the next); then compound 1; then compound 2.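

In this assay the series now has its first single-point step, no change at the digits printed from compound 3 to compound 4 (within the scatter): atoms and bonds stay the same, and only one stereocentre at a saturated chain carbon goes from drawn R to no drawn configuration. The comparison rests on a single difference: the fact that one of compounds 3 and 4 is drawn with a defined configuration and the other without, at the place where they differ. Going by these compounds alone, at this position, then, the drawn configuration leaves the read-out at the one concentration tested within the scatter, something compounds 1 and 2 could not show, as no pair among the earlier compounds differs in one place only.

The compounds shown leave open how a carbon drawn S at this position would read, since a centre without a drawn configuration does not specify the form present. Also open, as far as these compounds go, is whether this flat result would hold with an amine, a carboxylic acid or a longer chain in place of the hydroxyl-bearing chain.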